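The source may report more compounds than this note shows. Statements on the series, on what has been measured and on what is new or still open speak of the compounds shown alone.

Working notes on the series. All three measured compounds share one core and differ only in the chain on the ring nitrogen: compound 1 `CCn1cnc2ncnc(N)c21` carries an ethyl chain, compound 2 `CCCn1cnc2ncnc(N)c21` a propyl chain, compound 3 `Nc1ncnc2ncn(CCO)c12` a 2-hydroxyethyl chain. In an assay on CHO cells for displacement of a labelled ligand from adenosine receptor A3 (Homo sapiens) (on this read-out lower numbers stand for stronger inhibition and higher numbers for weaker inhibition), compound 1 gives > 100000 nM, which is a limit of the assay and not a number. In this assay compound 2 gives > 100000 nM, again a limit. In this assay compound 3 gives > 100000 nM, also a limit. Compound 3 thus stands at the limit of > 100000 nM in this assay, at which 3 of the 3 values shown sit, with nothing on the numbers shown to set it apart from the other two. The steps a step that the two limits leave unreadable from compound 1 to compound 2, a step that the two limits leave unreadable from compound 1 to compound 3 and a step that the two limits leave unreadable from compound 2 to compound 3 are all unreadable, each running between two limits.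

Compound 4 `Nc1ncnc2ncn(CCCO)c12` extends the chain of compound 3: hydroxymethyl in place of hydroxy on a saturated chain carbon, two bonds along the chain from an aromatic nitrogen. Among the compounds with values here, no measured step speaks to this change with a readable size; the nearest one, a step that the two limits leave unreadable from compound 2 to compound 3, is itself unreadable. Neither a direction nor a size can be expected beyond the scatter on what is known. Compound 4 is therefore estimated at 150000 nM, most likely once more a limit, within 30000 nM to 1000000 nM. The step that the limit leaves unreadable from compound 3 to compound 4 is expected to stay within the scatter, with no readable direction.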

Compound 4, inhibition constant: > 100000 nM
Compound 4: only a limit was reported (the forecaster's own chance of this, stated with the estimate: 85%); the middle value is on the limit's open side.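

In this assay, within the data shown here, compound 4, like compound 1, compound 2 and compound 3, gives only a limit of the assay, so no step from any of them to compound 4 can be read. The compounds shown leave open which chain on the shared core, if any, would give a measurable value in this assay at all.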